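Notes on the series: nitro removal from compound 3

The source may hold more compounds than are shown below. What is called first, only, known or untested is meant among the compounds shown, and "the series" means these compounds.

For the measured compounds named here, compound 3 `COc1cc(OC)c(OC)cc1/C=C/C(=O)c1cccc([N+](=O)[O-])c1` gives 101000 nM in a functional assay on SW982 cells (Homo sapiens) for inhibition, read by MTT assay, with a stated time of 72 h (a higher number here means a weaker inhibitor, a lower number a stronger inhibitor), the second highest of the three numbers so far; compound 1 `COc1cc(OC)c(OC)cc1/C=C/C(=O)c1ccc(C)cc1` gives 81100 nM and compound 2 `COc1cc(OC)c(OC)cc1/C=C/C(=O)c1ccc(O)cc1` gives 155000 nM, and both stand within the scatter of compound 3. Going by the values given here, the only measured step, a 1.9-fold higher number from compound 1 to compound 2 (0.28 log units; within the scatter), also stays within the scatter. Compound 4 `COc1cc(OC)c(OC)cc1/C=C/C(=O)c1ccccc1` differs from compound 3 by hydrogen in place of nitro on an aromatic carbon. Among the compounds with values here, no measured step removes a substituent altogether, yet the one substitution seen moved the number little, and the three numbers themselves sit close together, so no shift beyond the scatter is expected in this assay for compound 4, a 1.1-fold lower number from compound 3 to compound 4 (0.03 log units; within the scatter). Compound 4 is therefore expected to give 95000 nM, with a range from 40000 nM to 220000 nM.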

Compound 4, half-maximal inhibitory concentration: > 150000 nM
Compound 4: a limit, no number (the forecaster's own chance of this, stated with the estimate: 15%); at least 1.5-fold (0.19 log units) between middle value and limit.
By their numbers in this assay, from the lowest: compounds 1, 3 and 2 (each within the scatter of the next).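

Compound 4, with hydrogen in place of nitro, gives a limit of the assay and not a number: the limit of > 150000 nM in this assay, at which 1 of the 4 values shown sits. Removing the substituent altogether therefore brings no lower number, and the two readable steps, an at least 1.4-fold higher number from compound 3 to compound 4 (0.17 log units; that floor lies within the scatter) and an at least 1.8-fold higher number from compound 1 to compound 4 (0.26 log units; that floor lies within the scatter), give floors only, so neither nitro nor methyl is shown to matter. The step between compound 2 and compound 4 cannot be read.

From the compounds shown here alone, the true size of both readable steps stays open. So does whether an amine or a carboxylic acid on this aromatic carbon would move the number beyond the scatter.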